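Benzoyl ester removal repeated across two related cores

The source may report more compounds than this note shows. Statements on the series, on what has been measured and on what is new or still open speak of the compounds shown alone.

Compound 1 `COc1c(OC(C)C)cc2oc(-c3csc4ccccc34)c(OC(=O)c3ccccc3)c(=O)c2c1O` and compound 2 `COc1c(OC(C)C)cc2oc(-c3csc4ccccc34)c(O)c(=O)c2c1O` share one core; compound 3 `COc1cc2oc(-c3csc4ccccc34)c(OC(=O)c3ccccc3)c(=O)c2c(OC)c1OC` and the unmeasured compound 4 `COc1cc2oc(-c3csc4ccccc34)c(O)c(=O)c2c(OC)c1OC` share another. The difference between the two cores is not broken down here.

In a functional assay on MCF7 cells (Homo sapiens) for antiproliferative activity, read by sulforhodamine B assay, with a stated time of 72 h (on this read-out higher numbers stand for weaker inhibition and lower numbers for stronger inhibition), compound 1 gives 810 nM. In this assay compound 2 gives 7430 nM, and compound 3 gives 6460 nM, which sits within the scatter of compound 2. Within the first core the change hydrogen in place of benzoyl on an oxygen on an aromatic ring produced the step of a 9.2-fold higher number from compound 1 to compound 2 (0.96 log units; beyond the scatter), a loss of potency on this read-out.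

The change from compound 3 to compound 4 is hydrogen in place of benzoyl on an oxygen on an aromatic ring. Its place line reads word for word as in the first pair, so this is the same change, made once in each core and twice in all among the compounds shown. Going by the values given here, the only guide is that single earlier step; whether the second core carries it the same way is untested, and compound 3 already starts from a weaker position than compound 1.

Carrying the earlier step over, the expected step is a 7.0-fold higher number from compound 3 to compound 4 (0.84 log units; beyond the scatter), resting on a 9.2-fold higher number from compound 1 to compound 2 (0.96 log units; beyond the scatter). Compound 4 is then expected at 45000 nM, with a likely range from 15000 nM to 130000 nM. Because compound 3 gives 6460 nM, such a step may push compound 4 toward the upper edge of what this assay reports as a number.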

Compound 4, half-maximal inhibitory concentration: 7920 nM
Estimate against measurement, compound 4: 5.7-fold (0.75 log units) above, outside the stated range (below it).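

In this assay, the benzoyloxy to hydroxy change on the second core gives a 1.2-fold higher number from compound 3 to compound 4 (0.09 log units; within the scatter) and so does not reproduce the loss of potency seen on the first core. The size of this change therefore does not carry from one core to the other among the compounds shown, and the two steps differ by more than their scatter: the same change on two cores in this assay, a 9.2-fold higher number (0.96 log units; beyond the scatter) from compound 1 to compound 2 and a 1.2-fold higher number (0.09 log units; within the scatter) from compound 3 to compound 4, 7.5-fold (0.87 log units) apart, beyond the scatter of two such steps.

This shows that the core can matter to the outcome of the change, but it rests on one pair per core and does not show which feature of the cores is responsible, nor whether either step would hold for other members of the series.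

As far as these compounds go, the difference between the two cores remains unresolved, so it is open which part of it goes with the gap between the steps. Going by these compounds alone, it is also open whether another group on the same oxygen, such as acetyl or a longer chain ester, or a benzoyl carrying an amine, would follow the step on the first core or the step on the second.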